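Isobutoxy to (2-methylprop-2-en-1-yl)oxy on the shared core

A few compounds are considered here, and "the series" means these few. Any claim that something is new, unique, unknown or untested is made for them only; others in the source may bear on it.

Measured so far:
compound 1 `N#Cc1c(N)nc(SCc2cccc(C(N)=O)c2)c(C#N)c1-c1ccc(OCC2CC2)cc1` gives 83 nM
compound 2 `CC(C)COc1ccc(-c2c(C#N)c(N)nc(SCC(N)=O)c2C#N)cc1` gives 603 nM

In an assay on CHO cells for displacement of a labelled ligand from adenosine receptor A1 (Homo sapiens), read by scintillation counting, with a stated time of 90 min (a higher number here means a weaker inhibitor, a lower number a stronger inhibitor), compound 2 holds the higher of the two numbers; compound 1 sits lower by a margin beyond the usual scatter, so compound 2 is the weaker inhibitor of the pair.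

Compound 3 `C=C(C)COc1ccc(-c2c(C#N)c(N)nc(SCC(N)=O)c2C#N)cc1` differs from compound 2 by 1-methylethenyl in place of isopropyl on a saturated chain carbon bound to an oxygen on an aromatic ring. Among the measured compounds shown here, no measured pair shows this change, so no step on record guides it. The shift expected from compound 2 to compound 3 in this assay is small, without a clear direction, most likely within the scatter: a 1.1-fold lower number from compound 2 to compound 3 (0.04 log units; within the scatter). Compound 3 is therefore estimated at 550 nM, with a range from 220 nM to 1400 nM.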

Compound 3, inhibition constant: 872 nM
Beside the measured number, compound 3's estimate is 1.6-fold (0.20 log units) below it; the measured number falls inside the stated range.
By their numbers in this assay, from the lowest: compound 1; then compounds 2 and 3 (each within the scatter of the next).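

In this assay, 1-methylethenyl in place of isopropyl on a saturated chain carbon bound to an oxygen on an aromatic ring gives a 1.4-fold higher number from compound 2 to compound 3 (0.16 log units; within the scatter). Among the compounds shown here, this is the first reading at this position, and on this single pair a double bond outside aromatic rings in the entering group does not separate the two compounds beyond the scatter. Nothing available accounts for this result or bears on it.

Still open, as far as these compounds go, is whether an amine, a carboxylic acid or a longer chain at this place would shift the number beyond the scatter. From the compounds shown here alone, whether the same change reads alike on the core of compound 1 also stays open.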